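The source may hold more compounds than are shown below. What is called first, only, known or untested is meant among the compounds shown, and "the series" means these compounds.

Compound 2 `O=C1NCCC12CCN(c1c(-c3ccc4ncnn4c3)cnc3[nH]ccc13)CC2` is the weaker of the two measured compounds: in an assay on cells for binding affinity to Cyclin-C/Cyclin-dependent kinase 19 (Homo sapiens), read by LanthaScreen (on this read-out lower numbers stand for stronger inhibition and higher numbers for weaker inhibition), compound 2 gives 1020 nM, the highest of the two numbers. Among the measured compounds shown here, its nearest neighbour is compound 1 `Cn1cnc2cc(-c3cnc4[nH]ccc4c3N3CCC4(CCNC4=O)CC3)ccc21`, which in this assay gives 50 nM; the single measured step is a 20-fold higher number from compound 1 to compound 2 (1.31 log units; beyond the scatter), a large loss for exchanging one fused bicyclic group for another on the same aromatic carbon. Compound 3 `O=C1NCCC12CCN(c1c(-c3ccn4ccnc4c3)cnc3[nH]ccc13)CC2` continues the series at that position: a group of 9 heavy atoms (7 carbon, 2 nitrogen; one five-membered aromatic ring with 2 hetero atoms, one six-membered aromatic ring with 1 hetero atom) in place of a group of 9 heavy atoms (6 carbon, 3 nitrogen; one five-membered aromatic ring with 3 hetero atoms, one six-membered aromatic ring with 1 hetero atom), on an aromatic carbon. For the measured compounds named here, the only measured step that bears on this change is the one from compound 1 to compound 2, and it shows that the group on this aromatic carbon can shift the number by a large amount. The group entering compound 3 lies between the groups of compound 1 and compound 2 in its count of carbon and nitrogen atoms, so a step down, but a modest one, is expected: a 2.0-fold lower number from compound 2 to compound 3 (0.31 log units; beyond the scatter). Compound 3 is therefore estimated at 500 nM, with a range from 150 nM to 2000 nM.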

Compound 3, half-maximal inhibitory concentration: 68 nM
Estimate against measurement, compound 3: 7.4-fold (0.87 log units) above; measured number outside the range, below it.
By their numbers in this assay, from the lowest: compounds 1 and 3 (each within the scatter of the next); then compound 2.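

In this assay the step of a 15-fold lower number from compound 2 to compound 3 (1.18 log units; beyond the scatter) is large even though the group leaving and the group entering have the same heavy-atom count and the same ring sizes, differing only in 6 carbon, 3 nitrogen against 7 carbon, 2 nitrogen. Thus the earlier loss at this aromatic carbon does not follow from a six-membered aromatic ring with 1 hetero atom as such, and the step of a 1.4-fold higher number from compound 1 to compound 3 (0.13 log units; within the scatter) lies within the scatter, so a group with such a ring can read like the group with a six-membered aromatic ring of carbon only. No measurement here accounts for the size of either step.

From the compounds shown here alone, whether the fused five-membered ring is needed at all remains open. A plain pyridine, or a phenyl carrying an amine, at this place would test that.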